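The compounds below may be only part of what the source reports. "The series", "measured", "known", "first", "only" and "open" are said of these compounds alone.

Measured so far:
compound 1 `CC(C)(C)C(=O)N1CCCn2nc(COc3ccccc3)cc21`: 64%
compound 2 `O=C(C1CCCC1)N1CCCn2nc(COc3ccccc3)cc21`: 41%
compound 3 `O=C(c1ccccc1)N1CCCn2nc(COc3ccccc3)cc21`: 63%

In a functional assay on HEK293 cells for positive allosteric modulation of metabotropic glutamate receptor 5 (Homo sapiens), read by calcium flux (on this read-out lower numbers stand for smaller maximal responses and higher numbers for larger maximal responses), compound 1 gives the highest of the three numbers, though compound 3 sits within the scatter of it: a number 1 percentage points lower from compound 1 to compound 3 (within the scatter). Compound 2 is the outlier on the low side, a number 23 percentage points lower from compound 1 to compound 2 (beyond the scatter), and the return to an aryl amide recovers it, a number 22 percentage points higher from compound 2 to compound 3 (beyond the scatter). On these three points a cyclopentyl amide reads lower, while tert-butyl and phenyl amides read alike.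

Compound 4 `O=C(c1ccccc1F)N1CCCn2nc(COc3ccccc3)cc21` is the next member to be measured. It differs from compound 1 in one place: 2-fluorophenyl in place of tert-butyl on a carbonyl carbon. Among the compounds with values here, the step that bears on it is the one from compound 1 to compound 3, where phenyl replaced tert-butyl with no change beyond the scatter. Within the data shown here, no measured compound carries a fluorine on this ring, so any contribution of the fluorine itself is unknown. The expected step is therefore small, a number 4 percentage points lower from compound 1 to compound 4 (within the scatter), likely within the scatter. Compound 4 is estimated at 60%, with a range from 45% to 75%.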

Compound 4, largest response reached (reported as percent of maximum), in percent of the reference or control that the assay uses: 62%
Beside the measured number, compound 4's estimate is 2 percentage points below it, within the range that was stated.
By their numbers in this assay, from the lowest: compound 2; then compounds 4, 3 and 1 (each within the scatter of the next).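

In this assay, fluoro in place of hydrogen on an aromatic carbon of the phenyl amide gives no step beyond the scatter (a number 1 percentage points lower from compound 3 to compound 4 (within the scatter)), so this ring carries the fluoro group with the read-out level. The 2-fluorophenyl amide also reads alike with the tert-butyl amide (a number 2 percentage points lower from compound 1 to compound 4 (within the scatter)) and stands clear of the cyclopentyl amide (a number 21 percentage points higher from compound 2 to compound 4 (beyond the scatter)), which leaves the cyclopentyl amide as the only one of the four amides that reads apart. No measurement at hand gives a reason for these steps.

Going by these compounds, what a methoxy group or a nitrile on this phenyl ring would do stays open, as does an amine or a carboxylic acid on the acyl group. These four amides vary only on the carbonyl carbon, so they say nothing about changes elsewhere in the shared core.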